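Swapping an open amine for a ring on the side chain

This account rests on a few compounds, and the source may have more. Where it says the series, first, only, none or still open, it means among the compounds named here.

- Compound 1 `COc1cc2oc(-c3ccccc3)cc(=O)c2c(O)c1OCCCN1CCCCC1`: 17000 nM
- Compound 2 `CCN(CC)CCCCOc1c(OC)cc2oc(-c3ccccc3)cc(=O)c2c1O`: 35000 nM
- Compound 3 `CN1CCN(CCCOc2c(OCc3ccccc3)cc3oc(-c4ccccc4)cc(=O)c3c2O)CC1`: 1300 nM

In a functional assay on A549 cells (Homo sapiens) for antiproliferative activity, read by MTT assay, with a stated time of 48 h (on this read-out lower numbers stand for stronger inhibition and higher numbers for weaker inhibition), compound 2 has the highest number of the three, at 35000 nM. Compound 4 `COc1cc2oc(-c3ccccc3)cc(=O)c2c(O)c1OCCCN1CCCC1` has not been measured. It differs from compound 2 as follows: pyrrolidin-1-yl in place of (diethylamino)methyl on a saturated chain carbon, three bonds along the chain from an oxygen on an aromatic ring. In words, pyrrolidin-1-yl replaces (diethylamino)methyl on a saturated chain carbon, three bonds along the chain from an oxygen on an aromatic ring. For the measured compounds named here, one measured step bears on this: a 2.1-fold higher number from compound 1 to compound 2 (0.31 log units; beyond the scatter), where (diethylamino)methyl replaced piperidin-1-yl at that same place. Reversing that open group for a ring suggests a similarly modest drop in this assay, though this rests on a single step. The expected change is a 1.9-fold lower number from compound 2 to compound 4 (0.29 log units; within the scatter). For compound 4 the estimated value is 18000 nM, with an expected range of 8000 nM to 40000 nM.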

Compound 4, half-maximal inhibitory concentration: 6000 nM
The estimate for compound 4 lay 3.0-fold (0.48 log units) above the measured number; the measured number lies below the stated range.
By their numbers in this assay, from the lowest: compound 3; then compound 4; then compound 1; then compound 2.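

In this assay, closing the open amine into a ring at this place counts for more than the earlier step showed, giving a 5.8-fold lower number from compound 2 to compound 4 (0.77 log units; beyond the scatter) at the chain end. Ring choice also counts, since pyrrolidin-1-yl in place of piperidin-1-yl gives a 2.8-fold lower number from compound 1 to compound 4 (0.45 log units; beyond the scatter) on the same chain. Nothing available explains why these side chains rank as they do.

As far as these compounds go, how a morpholin-4-yl group would fare at this place remains open. So does whether pyrrolidin-1-yl would keep its lead on a longer chain.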